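From cyclopentylamino to piperidin-1-yl on a carbonyl carbon

The compounds below may be only part of what the source reports. "The series", "measured", "known", "first", "only" and "open" are said of these compounds alone.

Among the measured compounds shown here, in a functional assay on B16 cells (Mus musculus) for inhibition (on this read-out lower numbers stand for stronger inhibition and higher numbers for weaker inhibition), compound 1 `O=C(/C=C/c1ccc(O)c(O)c1)NC1CCCC1` gives 30000 nM, the highest of the three numbers so far. Compound 2 `O=C(/C=C/c1ccc(O)c(O)c1)NC1CCCCC1` gives 2800 nM and compound 3 `Cc1cccc(CNC(=O)/C=C/c2ccc(O)c(O)c2)c1` gives 3000 nM. Compound 4 `O=C(/C=C/c1ccc(O)c(O)c1)N1CCCCC1` has the same atoms as compound 1, joined differently: piperidin-1-yl in place of cyclopentylamino on a carbonyl carbon. For the measured compounds named here, the one measured step that bears on this is large: an 11-fold lower number from compound 1 to compound 2 (1.03 log units; beyond the scatter), with cyclohexyl in place of cyclopentyl on an amide-type nitrogen. Going by the values given here, that step does not cover a ring holding the nitrogen, and no measured compound shows this change. A smaller step in the same direction is therefore expected in this assay: a 3.8-fold lower number from compound 1 to compound 4 (0.57 log units; beyond the scatter). For compound 4 the estimated value is 8000 nM, with an expected range from 2000 nM to 30000 nM.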

Compound 4, half-maximal inhibitory concentration: 24000 nM
Estimate against measurement, compound 4: 3.0-fold (0.48 log units) below; the measured number falls inside the stated range.
By their numbers in this assay, from the lowest: compounds 2 and 3 (each within the scatter of the next); then compounds 4 and 1 (each within the scatter of the next).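

In this assay, replacing cyclopentylamino with piperidin-1-yl on the carbonyl carbon removes the amide hydrogen and brings in a six-membered ring, yet gives only a 1.3-fold lower number from compound 1 to compound 4 (0.10 log units; within the scatter). At this position, then, the amide hydrogen can go without a step beyond the scatter, and a six-membered ring alone does not reproduce an 11-fold lower number from compound 1 to compound 2 (1.03 log units; beyond the scatter). Nothing available explains this result. The compounds shown leave open how morpholin-4-yl, with a ring oxygen, or 4-hydroxypiperidin-1-yl would compare with compound 4 on the same carbonyl carbon.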